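The source may hold more compounds than are shown below. What is called first, only, known or untested is meant among the compounds shown, and "the series" means these compounds.

Working notes on the series. For the measured compounds named here, compound 1 `c1ccc2c(-c3nnc(-c4ccncc4)o3)c[nH]c2c1` is the only member with a full number: in a functional assay on DU-145 cells (Homo sapiens) for cytotoxicity, read by MTT assay (a higher number here means a weaker inhibitor, a lower number a stronger inhibitor), compound 1 gives 20400 nM. Compound 2 `Cc1nnc(-c2c[nH]c3ccccc23)o1` in this assay gives > 1000000 nM, which is a limit of the assay and not a number. On the numbers shown, compound 2 thus stands at the weak end of the pair, and the one measured step, an at least 49-fold higher number from compound 1 to compound 2 (1.69 log units; beyond the scatter), runs up to that limit (the limit of > 1000000 nM in this assay, at which 1 of the 2 values shown sits). Compound 3 `FC(F)(F)c1nnc(-c2c[nH]c3ccccc23)o1` is not yet measured; it differs from compound 2 by trifluoromethyl in place of methyl on an aromatic carbon. Going by the values given here, no measured step covers this exchange: the only step in hand swaps a pyridin-4-yl for a methyl, so it sets neither size nor direction for a methyl to trifluoromethyl change. Since compound 2 sits at a limit, the expected step of an at least 2.5-fold lower number from compound 2 to compound 3 (0.39 log units; beyond the scatter) is read as a guess only. Compound 3 is estimated at 400000 nM in this assay, in the range 40000 nM to 3000000 nM, with a real chance that the assay again returns only a limit.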

Compound 3, half-maximal inhibitory concentration: > 1000000 nM
Compound 3: only a limit was reported; the forecaster's own chance of this, stated with the estimate: 55%; middle value at least 2.5-fold (0.39 log units) from the limit.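

In this assay trifluoromethyl in place of pyridin-4-yl on this aromatic carbon gives an at least 49-fold higher number from compound 1 to compound 3 (1.69 log units; beyond the scatter) and so a second group besides methyl falls short of compound 1 at this position. Compound 2 and compound 3 both stand at a limit, the step between them cannot be read, and methyl and trifluoromethyl cannot be ranked against each other. Of the three compounds only compound 1 gives a full number, and the other two share one limit: the limit of > 1000000 nM in this assay, at which 2 of the 3 values shown sit.

The compounds shown leave open whether a phenyl ring on this carbon would keep a full number like that of compound 1, which would separate the aromatic ring of pyridin-4-yl from its nitrogen. From the compounds shown here alone, how an amine or a longer chain on this carbon would read also remains open.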